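Swapping the Aromatic Substituent in the Hydroxamic Acid Series

The compounds below may be only part of what the source reports. "The series", "measured", "known", "first", "only" and "open" are said of these compounds alone.

Compound 1 `Nc1ccc(NC(=O)CCCCCCC(=O)NO)cc1`: 8500 nM
Compound 2 `N#Cc1ccc(NC(=O)CCCCCCC(=O)NO)cc1`: 8800 nM

Both values come from a functional assay on SK-BR-3 cells (Homo sapiens) for antiproliferative activity, with a stated time of 48 h; on this read-out lower numbers stand for an effect already at smaller amounts and higher numbers for an effect only at larger amounts of compound. On these numbers, compound 2 at 8800 nM cannot be separated from compound 1 at 8500 nM, as the two lie within the scatter of each other.

The next compound to be read is compound 3 `CN(C)c1ccc(NC(=O)CCCCCCC(=O)NO)cc1`. It differs from compound 2 by dimethylamino in place of cyano on an aromatic carbon, with dimethylamino in place of cyano on an aromatic carbon, para to a large group.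

For the measured compounds named here, one measured step bears on this change: a 1.0-fold higher number from compound 1 to compound 2 (0.02 log units; within the scatter), which is cyano in place of amino on an aromatic carbon. That step lies within the scatter, so exchanging these two groups left the read-out unresolved. Dimethylamino itself has no measured precedent, which leaves the expectation resting on this single step.

In this assay the expected outcome is a 1.1-fold lower number from compound 2 to compound 3 (0.04 log units; within the scatter), so no change beyond the scatter is expected in either direction. For compound 3 the estimated value is 8000 nM, with an expected range of 3500 nM to 16000 nM.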

Compound 3, half-maximal effective concentration: 4200 nM
For compound 3 the middle estimate is 1.9-fold (0.28 log units) above the measured one; low and high end bracket the measured number.
By their numbers in this assay, from the lowest: compound 3; then compounds 1 and 2 (each within the scatter of the next).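

At the aromatic carbon para to a large group, the substituent can now move the read-out in this assay beyond the scatter, which the amino and cyano pair alone did not show. Dimethylamino in place of cyano gives a 2.1-fold lower number from compound 2 to compound 3 (0.32 log units; beyond the scatter) as a modest step, and dimethylamino in place of amino gives a 2.0-fold lower number from compound 1 to compound 3 (0.31 log units; beyond the scatter) as a modest step of similar size, so compound 3 stands apart from two neighbours that remain within the scatter of each other. Nothing on hand indicates what lies behind this separation.

Going by these compounds, whether the lower number belongs to dimethylamino specifically stays open: methylamino, diethylamino or morpholine on the same aromatic carbon would show whether the two methyl groups matter or whether other substituted amines read the same way. Also open is whether the step from cyano or amino to dimethylamino carries over to a shorter or longer chain between the amide and the hydroxamic acid, since all three compounds shown share one chain length.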